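The compounds below may be only part of what the source reports. "The series", "measured", "known", "first", "only" and "open" are said of these compounds alone.

In an in vitro ADME assay on microsomes from liver (Rattus norvegicus) for metabolic stability, tested at 1 uM (on this read-out lower numbers stand for a shorter-lived compound and higher numbers for a longer-lived compound), compound 1 `CC(C)(O)CCN1CCC(NS(=O)(=O)c2cc(S(=O)(=O)c3ccccc3)ccc2C(F)(F)F)CC1` gives 0.05 h. From the compounds shown here alone, compound 2 `O=C([C@H]1CCNC1)N1CCC(NS(=O)(=O)c2cc(S(=O)(=O)c3ccccc3)ccc2C(F)(F)F)CC1` gives > 0.5 h, which is a limit of the assay and not a number, so its exact position is unknown. This is the limit of > 0.5 h in this assay, at which 1 of the 2 values shown sits. Compound 3 `O=C([C@@H]1CCNC1)N1CCC(NS(=O)(=O)c2cc(S(=O)(=O)c3ccccc3)ccc2C(F)(F)F)CC1` has the same atoms and bonds as compound 2, and the change is the two compounds have the same atoms and bonds and differ only in configuration as drawn: 1 of 1 stereo elements differ; a stereocentre at a saturated ring carbon is drawn S in compound 2 and R in compound 3. Within the data shown here, the only measured step, an at least 10-fold higher number from compound 1 to compound 2 (1.00 log units; beyond the scatter), is large, but it exchanges 3-hydroxy-3-methylbutyl for (pyrrolidin-3-yl)carbonyl on an amine nitrogen in a ring. It involves no change in configuration, so it gives no direct measure for this pair. No step beyond the scatter is therefore expected in this assay, in either direction. The estimated step, a step that the limit leaves unreadable from compound 2 to compound 3, is expected to stay within the scatter. For compound 3 the estimate is 0.6 h, with an expected range from 0.25 h to 1.2 h.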

Compound 3, half-life: > 0.5 h
Compound 3: a limit, no number; the forecaster's own chance of this, stated with the estimate: 70%; the middle value does not contradict the limit.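

In this assay compound 3 gives > 0.5 h, which is a limit of the assay and not a number. Placing (pyrrolidin-3-yl)carbonyl instead of 3-hydroxy-3-methylbutyl on the amine nitrogen in a ring gives an at least 10-fold higher number from compound 1 to compound 3 (1.00 log units; beyond the scatter), so the gain seen with the stereocentre drawn S also holds with it drawn R. The step between compound 2 and compound 3 cannot be read, and any difference between the two configurations stays hidden, because both values stop at the same limit: the limit of > 0.5 h in this assay, at which 2 of the 3 values shown sit.

From the compounds shown here alone, how long either compound actually lasts in this test remains open, so the two cannot be put in order. Also open, going by these compounds, is how a smaller acetyl group on the same nitrogen would compare with (pyrrolidin-3-yl)carbonyl.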